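A few compounds are considered here, and "the series" means these few. Any claim that something is new, unique, unknown or untested is made for them only; others in the source may bear on it.

Measured compounds:
compound 1 `C=C[C@@](C)(/C=C/c1ccc(OC)cc1)CCC=C(C)C`: > 36600 nM
compound 2 `C=C[C@@](C)(/C=C/c1ccc(O)c(CO)c1)CCC=C(C)C`: > 36600 nM

In an ADME assay on HEK293 cells (Homo sapiens) for cytotoxicity, with a stated time of 72 h (a higher number here means that more compound is needed for the effect, a lower number that less compound is needed), compound 1 gives > 36600 nM, which is a limit of the assay and not a number. Compound 2 likewise gives only a limit, > 36600 nM, in this assay. Within the data shown here, both values therefore sit at the limit of > 36600 nM in this assay, at which 2 of the 2 values shown sit, and compound 1 stands where every value so far stands: at the limit, with no number to rank it.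

Compound 3 `C=C[C@@](C)(/C=C/c1ccc(-c2ccc(Cl)cc2)cc1)CCC=C(C)C` is not yet measured in this assay. It differs from compound 1 in one place: 4-chlorophenyl in place of methoxy on an aromatic carbon.

Among the measured compounds shown here, no step between measured compounds exists to guide the expectation. From compound 1 to compound 3 a step toward a lower number is expected, or none beyond the scatter, which would leave compound 3 at the limit as well: an at least 1.4-fold lower number from compound 1 to compound 3 (0.16 log units; that floor lies within the scatter). Compound 3 is accordingly estimated at 25000 nM in this assay, within a range from 8000 nM to 80000 nM.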

Compound 3, half-maximal effective concentration: > 36600 nM
Compound 3 gave a limit, no number; the forecaster's own chance of this, stated with the estimate: 55%; middle value at least 1.4-fold (0.16 log units) away from the limit.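

In this assay compound 3 gives > 36600 nM as a limit and not a number, and compound 1 also gives only a limit, so no step can be read between compound 1 and compound 3. The compounds shown leave open how far any of them differs from the others, since none has a number: the limit of > 36600 nM in this assay, at which 3 of the 3 values shown sit.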